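The source may hold more compounds than are shown below. What is called first, only, known or untested is meant among the compounds shown, and "the series" means these compounds.

Measured so far:
compound 1 `O=C(O)c1ccc2[nH]c(=O)c(=O)oc2c1`, 16000 nM
compound 2 `O=c1[nH]c2cc(C(F)(F)F)ccc2oc1=O`, 100000 nM
compound 3 `CCOC(=O)C(=O)Nc1ccc2oc(=O)c(=O)[nH]c2c1`, 60000 nM

In a functional assay with Rattus norvegicus as the target (a lower number here means a stronger inhibitor, a higher number a weaker inhibitor), compound 1 stands at the lowest of the three numbers; compound 3 gives a number beyond the scatter above it, and compound 2 lies further off still. The next compound, compound 4 `COc1ccc2[nH]c(=O)c(=O)oc2c1`, has not yet been tested in this assay. Compound 4 differs from compound 1 in one place: methoxy in place of carboxy on an aromatic carbon. Among the compounds with values here, no measured pair shows the same change, so the size of the step is uncertain. With the carboxy group gone, and with compound 2 and compound 3 both weaker than compound 1, a step towards a higher number is expected, a 2.5-fold higher number from compound 1 to compound 4 (0.40 log units; beyond the scatter). For compound 4 the expected value in this assay is 40000 nM, in a range from 10000 nM to 160000 nM.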

Compound 4, half-maximal inhibitory concentration: 28000 nM
Compound 4: the middle estimate sits 1.4-fold (0.15 log units) above what was measured, within the range that was stated.
By their numbers in this assay, from the lowest: compounds 1 and 4 (each within the scatter of the next); then compounds 3 and 2 (each within the scatter of the next).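

In this assay, the change to methoxy in place of carboxy on this aromatic carbon gives a 1.8-fold higher number from compound 1 to compound 4 (0.24 log units; within the scatter) and so does not separate the two groups. At this position the carboxy group, with its hydrogen-bond donor, is therefore not required to keep the number of compound 1, as methoxy carries no such donor. Nothing available explains this result. Still open, going by these compounds, is how an amine, a hydroxyl group or a longer alkoxy chain would read on this same carbon. On these data alone, whether a bare hydrogen there would give a similar number also remains unknown.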